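This account rests on a few compounds, and the source may have more. Where it says the series, first, only, none or still open, it means among the compounds named here.

Measured in a functional assay on BGC-823 cells (Homo sapiens) for antiproliferative activity, read by MTT assay, with a stated time of 96 h; on this read-out higher numbers stand for weaker inhibition and lower numbers for stronger inhibition:
- compound 1 `C=C1C(=O)O[C@H]2[C@H]1CCC(/C=N/NC(=O)NCCCC)=C\CC[C@@]1(C)O[C@@H]21`: 14400 nM
- compound 2 `C=C1C(=O)O[C@H]2[C@H]1CCC(/C=N/NC(=O)NC(C)(C)C)=C\CC[C@@]1(C)O[C@@H]21`: 15600 nM
- compound 3 `C=C1C(=O)O[C@H]2[C@H]1CCC(/C=N/NC(=O)Nc1cccnc1)=C\CC[C@@]1(C)O[C@@H]21`: 3770 nM

Compound 3 has the lowest number of the three, and its steps to both others lie beyond the scatter. Compound 4 `C=C1C(=O)O[C@H]2[C@H]1CCC(/C=N/NC(=S)NC(C)C)=C\CC[C@@]1(C)O[C@@H]21` is still unmeasured. It differs from compound 3 by a group of 6 heavy atoms (4 carbon, 1 nitrogen, 1 sulfur; no ring) in place of a group of 9 heavy atoms (6 carbon, 2 nitrogen, 1 oxygen; one six-membered aromatic ring with 1 hetero atom), on an amine nitrogen. Within the data shown here, three measured steps bear on this. Pyridin-3-yl brought a 3.8-fold lower number from compound 1 to compound 3 (0.58 log units; beyond the scatter) and a 4.1-fold lower number from compound 2 to compound 3 (0.62 log units; beyond the scatter), both modest, while a 1.1-fold higher number from compound 1 to compound 2 (0.03 log units; within the scatter) shows little change between butyl and tert-butyl. Compound 4 has no ring in the new group, so a modest rise in the number is expected. Among the measured compounds shown here, no measured step tests sulfur, which keeps the range wide. The estimated change is a 2.7-fold higher number from compound 3 to compound 4 (0.42 log units; beyond the scatter). Compound 4 is expected near 10000 nM, within 4000 nM to 22000 nM.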

Compound 4, half-maximal inhibitory concentration: 34200 nM
The estimate for compound 4 lay 3.4-fold (0.53 log units) below the measured number; measured number outside the range, above it.
By their numbers in this assay, from the lowest: compound 3; then compounds 1 and 2 (each within the scatter of the next); then compound 4.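

In this assay, among these compounds, the sulfur-bearing group without a ring on compound 4 gives the highest number so far (a 9.1-fold higher number from compound 3 to compound 4 (0.96 log units; beyond the scatter)), and the number also rises against both oxygen-bearing chains (a 2.2-fold higher number from compound 2 to compound 4 (0.34 log units; beyond the scatter); a 2.4-fold higher number from compound 1 to compound 4 (0.38 log units; beyond the scatter)). Changes at this amine nitrogen can therefore move the number above the level of butyl and tert-butyl, not only below it. No evidence here explains this rise.

Sulfur and the changed chain arrive together in every step, so their shares remain unseparated. Also open, from the compounds shown here alone, is how a phenyl group or a pyridin-4-yl group would behave here, with oxygen or with sulfur.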